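Compound 1 to Compound 4: a Ring Swap Without Measured Steps

The source may report more compounds than this note shows. Statements on the series, on what has been measured and on what is new or still open speak of the compounds shown alone.

Compound 1 `Nc1ccccc1NC(=O)c1ccc(NC(=S)NCc2cccc(F)c2)cc1` gives > 2000 nM in an assay on isolated protein for inhibition of Nicotinamide phosphoribosyltransferase (Homo sapiens), read by fluorescence, with stated times of 5 min and 15 min (on this read-out lower numbers stand for stronger inhibition and higher numbers for weaker inhibition), a limit of the assay rather than a number.
Compound 2 `Nc1ccccc1NC(=O)c1ccc(NC(=O)/C(Cl)=C(\Cl)c2cccnc2)cc1` gives > 2000 nM in this assay, again a limit.
Compound 3 `Nc1ccccc1NC(=O)c1ccc(NC(=O)NCc2ccc(F)nc2)cc1` gives > 2000 nM in this assay, again a limit.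

All three measured compounds share the same core and sit at the same limit, (the limit of > 2000 nM in this assay, at which 3 of the 3 values shown sit). Because of the limit of > 2000 nM in this assay, at which 3 of the 3 values shown sit, nothing separates compound 1 from compound 2 or compound 3 in this assay; compound 1 stands at the edge of what the assay reports, with no number of its own, and there is no measured step between any two of these compounds to build on.

Compound 4 `Cc1ccc(CNC(=S)Nc2ccc(C(=O)Nc3ccccc3N)cc2)cn1` differs from compound 1 in one place: 6-methylpyridin-3-yl in place of 3-fluorophenyl on a saturated chain carbon bound to an amide-type nitrogen. Among the measured compounds shown here, with no measured step and only limits in hand, the expected size of this step in this assay is none beyond the scatter, in no particular direction; the most likely outcome is that compound 4 also comes back as a limit.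

Compound 4 is therefore expected to give about 3000 nM in this assay, with a plausible range from 800 nM to 12000 nM. The step this estimate implies, a step that the limit leaves unreadable from compound 1 to compound 4, is likewise an expectation and not a measurement.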

Compound 4, half-maximal inhibitory concentration: > 2000 nM
Compound 4: no number, only a limit; the forecaster's own chance of this, stated with the estimate: 70%; the middle value does not contradict the limit.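

In this assay compound 4 gives > 2000 nM, a limit of the assay and not a number. No step from compound 1 to compound 4 can be read, because both compounds sit at the same limit: the limit of > 2000 nM in this assay, at which 4 of the 4 values shown sit.

The compounds shown leave open how strongly any of them inhibits the enzyme, and whether 6-methylpyridin-3-yl in place of 3-fluorophenyl changes that at all.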